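Compound 3: cyclohexylamino in place of dimethylamino

This account rests on a few compounds, and the source may have more. Where it says the series, first, only, none or still open, it means among the compounds named here.

In a functional assay on the whole organism with Mus musculus as the target (a lower number here means that less compound is needed, a higher number that more compound is needed for the effect), compound 1 `CNC(=O)/C=C(\C)c1cccc(C(F)(F)F)c1` gives a measured dose of 87.5 mg/kg as its half-maximal figure. Compound 2 `CN(C)C(=O)CCC(=O)c1cccc(C(F)(F)F)c1` gives only a limit (> 50 mg/kg) and no number. Compound 3 `O=C(CCC(=O)c1cccc(C(F)(F)F)c1)NC1CCCCC1` differs from compound 2 by cyclohexylamino in place of dimethylamino on a carbonyl carbon in one place: cyclohexylamino in place of dimethylamino on a carbonyl carbon. Among the compounds with values here, no measured step covers this change. In this assay the expected step is a step that the limit leaves unreadable from compound 2 to compound 3 and no shift beyond the scatter is expected. Compound 3 is estimated at 60 mg/kg with an expected range from 25 mg/kg to 140 mg/kg for the dose.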

Compound 3, dose for half-maximal effect: > 200 mg/kg
Compound 3 ended at the assay's limit; the forecaster's own chance of this, stated with the estimate: 45%; at least 3.3-fold (0.52 log units) between middle value and limit.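

Within the data shown here, compound 2 and compound 3 both give only limits, not numbers, so no step between them can be read. The compounds shown leave open whether cyclohexylamino in place of dimethylamino shifts the dose at all, and by how much.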